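Replacing a trifluoromethylcyclopropyl amide with an oxanyl amide

A few compounds are considered here, and "the series" means these few. Any claim that something is new, unique, unknown or untested is made for them only; others in the source may bear on it.

The series shares a urea-linked piperidine core capped by an amide. Compound 1 `CCOC(=O)N1CCC(NC(=O)Nc2ccc(OC(F)(F)F)c(F)c2)CC1` gives 5.94 in a physicochemical assay for lipophilicity, read by HPLC, with a stated time of 90 min, tested at 100 uM; on this read-out lower numbers stand for lower lipophilicity and higher numbers for higher lipophilicity. Compound 3 `CC[C@H](C)C(=O)N1CCC(NC(=O)Nc2ccc(OC(F)(F)F)c(Cl)c2)CC1` gives 7.7 in the same read-out. Compound 2 `O=C(Nc1ccc(C(F)(F)F)c(F)c1)NC1CCN(C(=O)C2(C(F)(F)F)CC2)CC1` gives 5.52 and stands lowest of the three numbers measured; its nearest neighbour is compound 1, which lies higher by an amount beyond the usual scatter, and compound 3 lies furthest above it, again beyond the scatter. Going by the values given here, no pair of these three differs in a single place, so no measured step can be drawn between them.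

Compound 4 `O=C(Nc1ccc(C(F)(F)F)c(F)c1)NC1CCN(C(=O)C2CCOCC2)CC1` has not yet been measured. It differs from compound 2 in one place: oxan-4-yl in place of 1-(trifluoromethyl)cyclopropyl on a carbonyl carbon. A six-membered ring carrying one hetero atom and one hydrogen-bond acceptor takes the place of a three-membered ring of carbon only bearing three fluorine atoms.

On the numbers available, a downward step is expected for compound 4, clearly beyond the scatter. The estimated step from compound 2 to compound 4 is a number 1.22 log units lower from compound 2 to compound 4 (beyond the scatter). Compound 4 is therefore expected to give about 4.3, with a likely range from 3.6 to 5.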

Compound 4, partition coefficient: 3.52
Estimate against measurement, compound 4: 0.78 log units above; measured number outside the range, below it.
By their numbers in this assay, from the lowest: compound 4; then compound 2; then compound 1; then compound 3.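

In this assay, going by these compounds alone, the exchange of 1-(trifluoromethyl)cyclopropyl for oxan-4-yl gives the first step that can be read: a number 2.00 log units lower from compound 2 to compound 4 (beyond the scatter), a large change. It shows that the group on this carbonyl carbon, whose other neighbours are the amide-type nitrogen in a ring, can by itself move the read-out this far while the rest of the molecule stays the same. The change also bundles several differences, since a three-membered ring of carbon only, bearing three fluorine atoms, leaves and a six-membered ring with one hetero atom and one hydrogen-bond acceptor enters, and this single pair cannot separate those differences.

No measured information available here accounts for the size of the step. Going by these compounds, a cyclohexyl or plain cyclopropyl group on the same carbonyl carbon would help to separate the part played by the ring oxygen from that of the fluorine atoms, while it remains open whether the same exchange gives a step of like size on the core of compound 3, or how a carboxylic acid or an amine on the ring would read.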